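This account rests on a few compounds, and the source may have more. Where it says the series, first, only, none or still open, it means among the compounds named here.

Measured so far:
compound 1, `O=C(NCc1ccc(-c2ccccc2)cc1)c1ccc[nH]1` — in a functional assay on NCI-H460 cells (Homo sapiens) for inhibition, read by MTT assay, with a stated time of 72 h (a lower number here means a stronger inhibitor of growth, a higher number a weaker inhibitor of growth), compound 1 gives > 50000 nM, which is a limit of the assay and not a number.
compound 2, `O=C(NCc1ccccc1)c1cc(Br)c(Br)[nH]1` — in this assay compound 2 gives 35000 nM.

Among the measured compounds shown here, compound 2 therefore holds the only actual number in this small set; the other entry is the limit of > 50000 nM in this assay, at which 1 of the 2 values shown sits. For the measured compounds named here, compound 1 and compound 2 differ from each other in more than one place, so their two values show only that compound 2 reaches a measurable number where compound 1 does not.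

The next compound is compound 3, `O=C(NCc1ccc(Cl)cc1)c1cc(Br)c(Br)[nH]1`. It is compound 2 with chloro in place of hydrogen on an aromatic carbon. Going by the values given here, no measured step of this kind exists in the set, so the size of the change in this assay has to be expected from the structural change alone: a small move, if any, perhaps toward stronger growth inhibition, but not confidently beyond the scatter of repeated measurements. Compound 3 is accordingly estimated at 25000 nM, with a plausible range from 8000 nM to 70000 nM. That estimate means a step of a 1.4-fold lower number from compound 2 to compound 3 (0.15 log units; within the scatter), which is expected to be modest.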

Compound 3, concentration for 50% growth inhibition: 28000 nM
Beside the measured number, compound 3's estimate is 1.1-fold (0.05 log units) below it; measured number inside the range.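

Chloro in place of hydrogen, on an aromatic carbon of a six-membered aromatic ring of carbon only and para to a large group, gives the first step in the series that can be read at one place, and in this assay that step is a 1.3-fold lower number from compound 2 to compound 3 (0.10 log units; within the scatter). This position therefore accepts chloro without a shift that can be told from the scatter of repeated measurements, which the earlier pair, differing in more than one place, could not show. Nothing measured on these compounds offers a property that would bear on this step.

On these data alone, a single group at a single position sets no trend, and it remains open whether a methoxy group, an amine or a carboxylic acid at the same place would move the number beyond the scatter. Compound 1 stands at > 50000 nM, a limit of the assay and not a number, and with its several differences from the other compounds it leaves the separate contribution of each of those differences open.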